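Benzyl thioether variation on the shared nucleoside core

The compounds below may be only part of what the source reports. "The series", "measured", "known", "first", "only" and "open" are said of these compounds alone.

Going by the values given here, in an assay on isolated protein for inhibition of Equilibrative nucleoside transporter 1 (Homo sapiens) (on this read-out lower numbers stand for stronger inhibition and higher numbers for weaker inhibition), compound 2 `N#Cc1ccc(CSc2ncnc3c2ncn3[C@@H]2O[C@H](CO)[C@@H](O)[C@H]2O)cc1` gives 4.57 nM, the lowest of the three numbers measured so far. Compound 1 `OC[C@H]1O[C@@H](n2cnc3c(SCc4ccccc4Br)ncnc32)[C@H](O)[C@@H]1O` gives 151 nM and compound 3 `O=[N+]([O-])c1ccccc1CSc1ncnc2c1ncn2[C@@H]1O[C@H](CO)[C@@H](O)[C@H]1O` gives 115 nM. The steps of a 33-fold lower number from compound 1 to compound 2 (1.52 log units; beyond the scatter) and a 25-fold higher number from compound 2 to compound 3 (1.40 log units; beyond the scatter) are both large, whereas a 1.3-fold lower number from compound 1 to compound 3 (0.12 log units; within the scatter) stays within the scatter. Compound 4 `OC[C@H]1O[C@@H](n2cnc3c(SCc4ccc(Cl)cc4Cl)ncnc32)[C@H](O)[C@@H]1O` differs from compound 2 by 2,4-dichlorophenyl in place of 4-cyanophenyl on a saturated chain carbon bound to a sulfur. Among the compounds with values here, both measured departures from 4-cyanophenyl, to 2-bromophenyl and to 2-nitrophenyl, raised the number strongly; no measured compound separates the contributions of the two chlorines. The step from compound 2 to compound 4 is therefore expected to be a rise beyond the scatter, a 13-fold higher number from compound 2 to compound 4 (1.12 log units; beyond the scatter). Compound 4 is estimated at 60 nM, with a range from 15 nM to 250 nM.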

Compound 4, inhibition constant: 4.37 nM
Beside the measured number, compound 4's estimate is 14-fold (1.14 log units) above it; the whole stated range lies above it.
By their numbers in this assay, from the lowest: compounds 4 and 2 (each within the scatter of the next); then compounds 3 and 1 (each within the scatter of the next).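

In this assay, going by these compounds alone, the step of a 1.0-fold lower number from compound 2 to compound 4 (0.02 log units; within the scatter) stays within the scatter, so 4-cyanophenyl is not the only group on this saturated chain carbon bound to a sulfur that gives a low number. The steps of a 26-fold lower number from compound 3 to compound 4 (1.42 log units; beyond the scatter) and a 35-fold lower number from compound 1 to compound 4 (1.54 log units; beyond the scatter) are both large, so a halogen on the ring does not by itself go with the higher number of compound 1. No measurement shown explains these steps.

As far as these compounds go, what a single chlorine would give remains open. So does the reading for an amine or a carboxylic acid on the ring.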